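Inverting One Stereocentre in a Peroxide Diterpenoid

The compounds below may be only part of what the source reports. "The series", "measured", "known", "first", "only" and "open" are said of these compounds alone.

Measured compounds:
compound 1 `C=CC(=C)[C@@H](C[C@H]1C(=C)CC[C@H]2[C@](C)(CO)CCC[C@]12C)OO`, 34400 nM
compound 2 `C=CC(=C)[C@@H](C[C@H]1C(=C)CC[C@@H]2[C@]1(C)CCC[C@@]2(C)C(=O)O)OO`, 38000 nM
compound 3 `Cc1cc2c(C(C)C)ccc(C)c2cc1O`, 54000 nM

In a functional assay on PC-3 cells (Homo sapiens) for inhibition, read by colorimetric assay and MTT assay (on this read-out higher numbers stand for weaker inhibition of growth and lower numbers for stronger inhibition of growth), compound 1 gives a number that lies within the scatter of both compound 2 and compound 3, so the three cannot be told apart on these data. For the measured compounds named here, the only single-point step measured, a 1.1-fold higher number from compound 1 to compound 2 (0.04 log units; within the scatter), swaps one group for another and stays within the scatter. Compound 4 `C=CC(=C)[C@H](C[C@H]1C(=C)CC[C@H]2[C@](C)(CO)CCC[C@]12C)OO` differs from compound 1 only in configuration: the two compounds have the same atoms and bonds and differ only in configuration as drawn: 1 of 5 stereo elements differ; a stereocentre at a saturated chain carbon is drawn R in compound 1 and S in compound 4. Going by the values given here, no measured step tests such an inversion, so the expectation rests on the shared core alone. With nothing pointing either way, a change of roughly a 1.2-fold higher number from compound 1 to compound 4 (0.07 log units; within the scatter) is expected, with wide uncertainty. Compound 4 is therefore estimated at 40000 nM, likely between 15000 nM and 110000 nM.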

Compound 4, concentration for 50% growth inhibition: 50900 nM
Beside the measured number, compound 4's estimate is 1.3-fold (0.10 log units) below it, within the range that was stated.
By their numbers in this assay, from the lowest: compounds 1, 2, 4 and 3 (each within the scatter of the next).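

Going from R to S at the saturated chain carbon gives a 1.5-fold higher number from compound 1 to compound 4 (0.17 log units; within the scatter) in this assay. For the compounds shown here, this is the first direct test of configuration at this position, and it shows no difference that can be separated from ordinary variation between repeat measurements. The pair isolates this single stereocentre: the fact that compounds 1 and 4 differ only in the configuration as drawn.

The compounds shown leave open whether the same inversion would read alike with carboxy in place of hydroxymethyl, as in compound 2. They also leave open how an amine in that place would read.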